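Pyrimidin-2-yl in Place of 5-Methylpyrazin-2-yl on the Carbonyl

The source may hold more compounds than are shown below. What is called first, only, known or untested is meant among the compounds shown, and "the series" means these compounds.

Compound 1 `Cc1cnc(C(=O)Nc2cccc3ccc(C)nc23)cn1` gives > 10000 nM in a functional assay on BXPC-3 cells (Homo sapiens) for inhibition, read by MTT assay, with a stated time of 72 h; a lower number here means a stronger inhibitor, a higher number a weaker inhibitor; that value is a limit of the assay, not a number.
Compound 2 `Cc1ccc2cccc(NC(=O)c3ncccn3)c2n1` gives > 10000 nM in this assay, again a limit rather than a number.
Compound 3 `Cc1cnc(C(=O)Nc2cc(OCCNC(=O)OC(C)(C)C)cc3cccnc23)cn1` gives 3670 nM in this assay.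

Compounds 1 and 2 share one core and differ only in that (pyrimidin-2-yl in place of 5-methylpyrazin-2-yl on a carbonyl carbon). The step that the two limits leave unreadable from compound 1 to compound 2, because both sit at the limit of > 10000 nM in this assay, at which 2 of the 3 values shown sit, cannot be sized. Compound 3 differs from compound 1 in more than one place, and the difference between the two cores is not broken down here.

Compound 4 `CC(C)(C)OC(=O)NCCOc1cc(NC(=O)c2ncccn2)c2ncccc2c1` is still unmeasured. Relative to compound 3, (pyrimidin-2-yl in place of 5-methylpyrazin-2-yl on a carbonyl carbon). The place of this change reads the same as before, so it is the same change. Since the earlier step stayed unreadable, the step of a 1.2-fold higher number from compound 3 to compound 4 (0.09 log units; within the scatter) is expected to be small, resting on compound 3 at 3670 nM. Compound 4 is therefore estimated at 4500 nM, between 1500 nM and 13000 nM.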

Compound 4, half-maximal inhibitory concentration: > 10000 nM
Compound 4: a limit, no number; the forecaster's own chance of this, stated with the estimate: 35%; at least 2.2-fold (0.34 log units) between middle value and limit.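

On the second core, pyrimidin-2-yl in place of 5-methylpyrazin-2-yl on the carbonyl gives an at least 2.7-fold higher number from compound 3 to compound 4 (0.43 log units; beyond the scatter), so here the change weakens inhibition in this assay. Compound 4 gives > 10000 nM, a limit of the assay and not a number, so this step sets only a minimum size. Whether the change acts alike on both cores remains unknown, because the step between compound 1 and compound 2 cannot be read: the limit of > 10000 nM in this assay, at which 3 of the 4 values shown sit.

The compounds shown leave open what a free amine or a carboxylic acid in place of the chain of compound 3 would do to the value. Also open, as far as these compounds go, is whether the same ring change would give a fully readable step on such a core.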